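Swapping a long ester group for cyclopropyl

A few compounds are considered here, and "the series" means these few. Any claim that something is new, unique, unknown or untested is made for them only; others in the source may bear on it.

Two esters on a shared core have been tested for cytotoxicity. In a functional assay on A549 cells (Homo sapiens) for cytotoxicity, read by MTT assay, with a stated time of 48 h (a lower number here means a stronger inhibitor, a higher number a weaker inhibitor), compound 1 (`C=C1C(=O)O[C@H]2CC3=C[C@H](C/C(C)=C/[C@@H](OC(=O)c4ccc(-c5ccccc5)cc4)[C@H]12)OC3=O`) gives 4600 nM as a measured number. In this assay compound 2 (`C=C1C(=O)O[C@H]2CC3=C[C@H](C/C(C)=C/[C@@H](OC(=O)/C=C/c4ccc(N(C)C)cc4)[C@H]12)OC3=O`) gives > 10000 nM and this is a limit of the assay, not a number. Compound 2 therefore stands only at a limit, with no measured number to place it.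

Compound 3 (`C=C1C(=O)O[C@H]2CC3=C[C@H](C/C(C)=C/[C@@H](OC(=O)C4CC4)[C@H]12)OC3=O`) has not yet been measured. It differs from compound 2 as follows: cyclopropyl in place of 2-(4-(dimethylamino)phenyl)ethenyl on a carbonyl carbon; in words, cyclopropyl sits in place of 2-(4-(dimethylamino)phenyl)ethenyl on a carbonyl carbon. Among the measured compounds shown here, no measured step shows what such a change does. For the measured compounds named here, the only number available comes from compound 1 at 4600 nM and compound 3 is expected to land in that region. The estimated change is an at least 2.0-fold lower number from compound 2 to compound 3 (0.30 log units; that floor lies within the scatter) towards stronger inhibition. In this assay compound 3 is expected at 5000 nM with an estimated range of 1500 nM to 15000 nM as its likely span.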

Compound 3, half-maximal inhibitory concentration: 3200 nM
Compound 3: middle estimate off by 1.6-fold (0.19 log units), on the high side; measured number inside the range.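

In this assay, among the compounds shown here, putting cyclopropyl in place of 2-(4-(dimethylamino)phenyl)ethenyl on a carbonyl carbon gives an at least 3.1-fold lower number from compound 2 to compound 3 (0.49 log units; beyond the scatter), the first step that can be read at this position, and it shows that compound 3 reaches a measured number without the aromatic ring or the double bond of the group that leaves. Compound 2 stands at > 10000 nM, which is a limit of the assay and not a number. The step is therefore only a floor on the true change, because one end of it rests on that limit: the limit of > 10000 nM in this assay, at which 1 of the 3 values shown sits.

With a single step read, the compounds shown leave open whether the change follows from losing the dimethylamino group, the double bond or the aromatic ring, and how far the true value of compound 2 lies beyond the limit. They also do not tell what an open-chain isopropyl group, a cyclobutyl ring or a simple amine on the same carbonyl carbon would do in this assay.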